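Benzyl on the aminomethyl nitrogen of compound 3

The source may hold more compounds than are shown below. What is called first, only, known or untested is meant among the compounds shown, and "the series" means these compounds.

compound 1: `COc1cc(Nc2nc(Cl)cc3c(-c4ccccc4)n[nH]c23)cc(OC)c1OC`, 12.3 nM
compound 2: `COc1cc(Nc2nccc3c(-c4ccccc4)n[nH]c23)cc(OC)c1OC`, 5.13 nM
compound 3: `COc1cc(Nc2nc(CN)cc3c(-c4ccccc4)n[nH]c23)cc(OC)c1OC`, 4.9 nM

In a functional assay on Flp-In-CHO cells for antagonist activity at adenosine receptor A3 (Homo sapiens), read by cAMP accumulation, with a stated time of 30 min (a lower number here means a stronger inhibitor, a higher number a weaker inhibitor), compound 3 gives the lowest of the three numbers, though compound 2 sits within the scatter of it; only compound 1 is clearly apart, the step of a 2.5-fold lower number from compound 1 to compound 3 (0.40 log units; beyond the scatter) being modest. Compound 4, `COc1cc(Nc2nc(CNCc3ccccc3)cc3c(-c4ccccc4)n[nH]c23)cc(OC)c1OC`, differs from compound 3 by benzyl in place of hydrogen on an amine nitrogen. Among the measured compounds shown here, no measured step alters this amine nitrogen. The steps that touch the aminomethyl group at all are a 1.0-fold lower number from compound 2 to compound 3 (0.02 log units; within the scatter), within the scatter, and a 2.5-fold lower number from compound 1 to compound 3 (0.40 log units; beyond the scatter), modest. On that basis compound 4 is expected to show no step beyond the scatter, a 1.0-fold higher number from compound 3 to compound 4 (0.01 log units; within the scatter), with a wide range. Compound 4 is estimated at 5 nM, between 1.5 nM and 20 nM.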

Compound 4, half-maximal inhibitory concentration: 7.24 nM
Compound 4: the middle estimate sits 1.4-fold (0.16 log units) below what was measured; the measured number falls inside the stated range.
By their numbers in this assay, from the lowest: compounds 3, 2, 4 and 1 (each within the scatter of the next, the first and the last beyond it).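

Measured in this assay compound 4 shows that the amine nitrogen of compound 3 can carry benzyl with a 1.5-fold higher number from compound 3 to compound 4 (0.17 log units; within the scatter) and no step beyond the scatter. The (benzylamino)methyl group gives a 1.4-fold higher number from compound 2 to compound 4 (0.15 log units; within the scatter) against hydrogen and a 1.7-fold lower number from compound 1 to compound 4 (0.23 log units; within the scatter) against chloro, so compound 4, unlike compound 3, stands clear of neither compound. No available evidence accounts for this result. As far as these compounds go, whether a phenethyl group or a carboxylic acid on this nitrogen would give a step beyond the scatter remains open.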